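The source may report more compounds than this note shows. Statements on the series, on what has been measured and on what is new or still open speak of the compounds shown alone.

Compound 1 `CC1=CC[C@@H]([C@@](C)(O)CCCC(C)(C)NC=S)CC1`: 93700 nM
Compound 2 `CC1=CC[C@@H]([C@@](C)(O)CCCC(C)(C)NC(=S)NN)CC1`: > 100000 nM
Compound 3 `CC1=CC[C@@H]([C@@](C)(O)CCCC(C)(C)NC(=S)N/N=C\c2ccccc2)CC1`: 12900 nM

In a functional assay on OVCAR-3 cells (Homo sapiens) for cytotoxicity, read by sulforhodamine B assay (a lower number here means a stronger inhibitor of growth, a higher number a weaker inhibitor of growth), compound 3 has the lowest value of the three, at 12900 nM. Compound 2 stands at > 100000 nM, which is a limit of the assay and not a number. The measured steps that reach compound 3 are sizeable: a 7.3-fold lower number from compound 1 to compound 3 (0.86 log units; beyond the scatter), and an at least 7.7-fold lower number from compound 2 to compound 3 (0.88 log units; beyond the scatter). Both steps bring in the group with the six-membered aromatic ring.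

Compound 4 `CC1=CC[C@@H]([C@@](C)(O)CCCC(C)(C)NC(=S)N/N=C(/C)c2ccccc2)CC1` keeps that ring and differs only in the group on an amide-type nitrogen whose other neighbours are: thiocarbonyl carbon. The difference is a group of 9 heavy atoms (8 carbon, 1 nitrogen; one six-membered aromatic ring of carbon only) in place of a group of 8 heavy atoms (7 carbon, 1 nitrogen; one six-membered aromatic ring of carbon only), on an amide-type nitrogen. Going by the values given here, this is a far smaller change than either measured step, and no measured pair tests it directly. No shift beyond the scatter is therefore expected, and the expected change is a 1.2-fold lower number from compound 3 to compound 4 (0.07 log units; within the scatter). The estimated value for compound 4 is 11000 nM, with an expected range from 4500 nM to 28000 nM.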

Compound 4, concentration for total growth inhibition: 59500 nM
Compound 4: the middle estimate sits 5.4-fold (0.73 log units) below what was measured, outside the stated range (above it).
By their numbers in this assay, from the lowest: compound 3; then compounds 4 and 1 (each within the scatter of the next). At a limit, above all of these: compound 2.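

Keeping the six-membered aromatic ring is not enough to hold the gain seen with compound 3: on the amide-type nitrogen, the group of 9 heavy atoms in place of the group of 8 heavy atoms gives a clear loss (a 4.6-fold higher number from compound 3 to compound 4 (0.66 log units; beyond the scatter)). Going by these compounds alone, this place therefore responds to a far smaller change than the earlier steps, which brought in the whole ring. The other new step (an at least 1.6-fold lower number from compound 2 to compound 4 (0.22 log units; that floor lies within the scatter)) starts from a limit of the assay and not from a number, so it fixes only a floor: (the limit of > 100000 nM in this assay, at which 1 of the 4 values shown sits).

One pair cannot say whether the loss grows with the size of the group or why it occurs. An ethyl group on the same carbon that carries the ring, or a chlorine on the ring itself, would be the next test of how narrow this requirement is.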